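The compounds below may be only part of what the source reports. "The series", "measured", "known", "first", "only" and "open" are said of these compounds alone.

Compound 1 `O=C(Cc1csc2nc(-c3ccc(Br)cc3)cn12)N/N=C/c1ccc(O)cc1`: 61700 nM
Compound 2 `COc1cccc(OC)c1/C=N/NC(=O)Cc1csc2nc(-c3ccc(Br)cc3)cn12`: 35500 nM

Both numbers come from a functional assay on NCI/ADR-RES cells (Homo sapiens) for inhibition, read by sulforhodamine B assay, with a stated time of 48 h; on this read-out lower numbers stand for stronger inhibition of growth and higher numbers for weaker inhibition of growth. Compound 2 stands level with compound 1 within the usual scatter, so neither can be called the stronger of the two. Going by the values given here, the one measured step, a 1.7-fold lower number from compound 1 to compound 2 (0.24 log units; within the scatter), puts 2,6-dimethoxyphenyl in place of 4-hydroxyphenyl on a carbon with a double bond to nitrogen.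

Compound 3 `O=C(Cc1csc2nc(-c3ccc(Br)cc3)cn12)N/N=C/c1ccc(Cl)cc1Cl` has not yet been measured. It keeps the shared core of compound 2 and differs at that same place: 2,4-dichlorophenyl in place of 2,6-dimethoxyphenyl on a carbon with a double bond to nitrogen. In words, 2,4-dichlorophenyl stands in place of 2,6-dimethoxyphenyl on a carbon with a double bond to nitrogen.

Among the compounds with values here, no measured compound carries 2,4-dichlorophenyl, so the evidence is thin and the range must stay wide. Within the data shown here, still, the only exchange seen at this place, a 1.7-fold lower number from compound 1 to compound 2 (0.24 log units; within the scatter), stayed within the scatter, so no step beyond the scatter is expected in this assay, in either direction. The estimated step is a 1.1-fold higher number from compound 2 to compound 3 (0.05 log units; within the scatter). For compound 3 the estimated value is 40000 nM, with an expected range of 15000 nM to 90000 nM.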

Compound 3, concentration for total growth inhibition: 52500 nM
Beside the measured number, compound 3's estimate is 1.3-fold (0.12 log units) below it, and the stated range covers the measured number.
By their numbers in this assay, from the lowest: compounds 2, 3 and 1 (each within the scatter of the next).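

Compound 3 brings a third kind of ring to this place, and in this assay it separates from neither of the others: the exchange gives (a 1.5-fold higher number from compound 2 to compound 3 (0.17 log units; within the scatter)) and, measured against the hydroxylated ring, (a 1.2-fold lower number from compound 1 to compound 3 (0.07 log units; within the scatter)). The earlier pair showed only that a 2,6-dimethoxyphenyl and a 4-hydroxyphenyl group could not be told apart here, whereas all three compounds now sit within the scatter of one another, even though the 2,4-dichlorophenyl group carries chlorine instead of oxygen and has no hydrogen-bond acceptors, while the 2,6-dimethoxyphenyl group it replaces has 2. So, among these three rings on a carbon with a double bond to nitrogen, no exchange gives a real difference in this read-out, and nothing measured here offers an explanation for that.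

As far as these compounds go, it remains open whether a ring bearing an amine or a carboxylic acid, or a saturated group such as cyclohexyl in place of the aromatic ring, would move the number beyond the scatter. From the compounds shown here alone, all three compounds also share the same core, so what a change elsewhere in the molecule would do to growth inhibition also stays unknown.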